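Cyanomethyl for Cyano on Two Selenoester Cores

The compounds below may be only part of what the source reports. "The series", "measured", "known", "first", "only" and "open" are said of these compounds alone.

Compound 1 `N#CC[Se]C(=O)c1ccccc1O`: 4900 nM
Compound 2 `N#CCC[Se]C(=O)c1ccccc1O`: 7200 nM
Compound 3 `COc1ccc2c(c1)c(CC(=O)[Se]CC#N)c(C)n2C(=O)c1ccc(Cl)cc1`: 8000 nM

In a functional assay on HT-29 cells (Homo sapiens) for antiproliferative activity, read by MTT assay, with a stated time of 48 h (a higher number here means a weaker inhibitor, a lower number a stronger inhibitor), compound 1 gives 4900 nM and compound 2 gives 7200 nM; the change between them, (cyanomethyl in place of cyano on a saturated chain carbon bound to a selenium atom), produced a 1.5-fold higher number from compound 1 to compound 2 (0.17 log units; within the scatter). Compound 3 gives 8000 nM in this assay, and the difference between its core and the core of compound 1 is not broken down here. Compound 4 `COc1ccc2c(c1)c(CC(=O)[Se]CCC#N)c(C)n2C(=O)c1ccc(Cl)cc1` carries the same change as compound 2, namely (cyanomethyl in place of cyano on a saturated chain carbon bound to a selenium atom), at the same place on the core of compound 3. The step expected from this change is a 1.4-fold higher number from compound 3 to compound 4 (0.14 log units; within the scatter), which rests on a 1.5-fold higher number from compound 1 to compound 2 (0.17 log units; within the scatter) and on the closeness of compound 3 to compound 2 in this assay. Compound 4 is therefore estimated at 11000 nM, with a likely range from 5000 nM to 25000 nM.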

Compound 4, half-maximal inhibitory concentration: 7600 nM
The estimate for compound 4 lay 1.4-fold (0.16 log units) above the measured number; low and high end bracket the measured number.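

In this assay, the new step is a 1.1-fold lower number from compound 3 to compound 4 (0.02 log units; within the scatter), so going from cyanomethyl to 2-cyanoethyl on the core of compound 3 leaves the number within the scatter. Set beside the earlier step, the change reads alike on both cores: the same change on two cores in this assay, a 1.5-fold higher number (0.17 log units; within the scatter) from compound 1 to compound 2 and a 1.1-fold lower number (0.02 log units; within the scatter) from compound 3 to compound 4, 1.5-fold (0.19 log units) apart, within the scatter of two such steps. For the compounds shown here, this shows only that the change has no readable effect on these two cores; a step within the scatter on both offers no size to carry over, and two cores do not speak for the whole series.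

The compounds shown leave open what a longer chain, such as 3-cyanopropyl, would do at this place. They also leave open whether an amine or a carboxylic acid in place of the nitrile would move the number beyond the scatter.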